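Adding a Methoxy Group Where Every Value Sits at the Limit

The source may hold more compounds than are shown below. What is called first, only, known or untested is meant among the compounds shown, and "the series" means these compounds.

Of the compounds shown here, three have so far been tested in a functional assay on Malme-3M cells (Homo sapiens) for cytotoxicity, read by MTT assay, with a stated time of 6 days; a lower number here means that less compound is needed, a higher number that more compound is needed for the effect. Compound 1 `COc1cc(-c2oc3ccccc3c(=O)c2C(=O)O)cc(OC)c1OC` reaches only a limit of the assay, > 25 ug/mL. Compound 2 `COc1cc(OC)cc(-c2oc3ccccc3c(=O)c2C(=O)O)c1` likewise gives only a limit, > 25 ug/mL. Compound 3 `O=C(O)c1c(-c2ccc([N+](=O)[O-])cc2)oc2ccccc2c1=O` also stops at a limit, > 25 ug/mL. The change from compound 2 to compound 1, (methoxy in place of hydrogen on an aromatic carbon), yields a step that the two limits leave unreadable from compound 2 to compound 1, unreadable because of the limit of > 25 ug/mL in this assay, at which 3 of the 3 values shown sit. How the cores of compound 3 and compound 2 differ is not broken down here. Compound 4 `COc1ccc2oc(-c3ccc([N+](=O)[O-])cc3)c(C(=O)O)c(=O)c2c1`, not yet measured, differs from compound 3 by methoxy in place of hydrogen on an aromatic carbon; this is the same kind of change as that from compound 2 to compound 1, though here the place is part of a fused or bridged system of two rings, meta to a fused ring and para to a fused ring, rather than ortho to two methoxy groups and para to a large group. Compound 4 is expected to give about 35 ug/mL in this assay, with the likely range 15 ug/mL to 80 ug/mL, since compound 3 shows only the limit > 25 ug/mL. The expected step is estimated as a step that the limit leaves unreadable from compound 3 to compound 4.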

Compound 4, concentration for half-maximal effect: > 25 ug/mL
Compound 4 gave a limit, no number (the forecaster's own chance of this, stated with the estimate: 80%); the middle value lies beyond the limit too.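

Compound 3 and compound 4 both stop at a limit in this assay, so no new step can be read between them: the limit of > 25 ug/mL in this assay, at which 4 of the 4 values shown sit.

The compounds shown leave open whether methoxy in place of hydrogen on an aromatic carbon changes the concentration needed in this assay at all.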